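Ethoxy for fluoro on the core: a second small step

This account rests on a few compounds, and the source may have more. Where it says the series, first, only, none or still open, it means among the compounds named here.

Of the compounds shown here, two share a single core and have been tested in a functional assay on A-375 cells (Homo sapiens) for antiproliferative activity, read by MTT assay, with a stated time of 24 h, tested at 0.05 ug/mL; on this read-out higher numbers stand for a stronger effect at the one concentration tested and lower numbers for a weaker effect. Compound 1 `CCc1ccc2nc(C(=O)Nc3c(F)cc(-c4cccc(F)c4)cc3F)c(C)c(O)c2c1` carries an ethyl group on the fused ring, and in this assay compound 1 gives 0.68%. Compound 2 `Cc1c(C(=O)Nc2c(F)cc(-c3cccc(F)c3)cc2F)nc2ccc(F)cc2c1O` differs from it in one place, fluoro in place of ethyl on an aromatic carbon, and in this assay compound 2 gives 0.05%. Going by the values given here, the only step measured so far is a number 0.6 percentage points lower from compound 1 to compound 2 (within the scatter), so compound 2 and compound 1 sit within the scatter of each other, and neither can be called the more or less active of the two.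

Compound 3 `CCOc1ccc2nc(C(=O)Nc3c(F)cc(-c4cccc(F)c4)cc3F)c(C)c(O)c2c1` is the next member of the series. Its change from compound 2 is ethoxy in place of fluoro on an aromatic carbon. Among the compounds with values here, the one measured step bears on it only loosely, since it replaced ethyl by fluoro at the same aromatic carbon and stayed within the scatter. With both measured numbers close to zero and no step beyond the scatter in hand, no movement beyond the scatter is expected, and compound 3 is estimated to give 0.5%, within a range of -5% to 8%, a step of a number 0.5 percentage points higher from compound 2 to compound 3 (within the scatter) that is expected to stay within the scatter.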

Compound 3, a percentage reported as inhibition, at one concentration (the size of the read-out at that concentration, not a potency): 1.02%
Beside the measured number, compound 3's estimate is 0.5 percentage points below it, and the stated range covers the measured number.
By their numbers in this assay, from the lowest: compounds 2, 1 and 3 (each within the scatter of the next).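

Going by these compounds alone, at this aromatic carbon of the shared core, this assay now covers a third group, and it is the first to add an oxygen: ethoxy, with 3 heavy atoms and 1 hydrogen-bond acceptor, replaces fluoro, with 1 heavy atom and none, giving a number 1 percentage points higher from compound 2 to compound 3 (within the scatter). The comparison with ethyl gives the same kind of result, a number 0.3 percentage points higher from compound 1 to compound 3 (within the scatter), so fluoro, ethyl and ethoxy cannot be told apart at this position on this read-out, and neither the added oxygen nor the difference in size between these groups separates the compounds here. Nothing available bears on why these three numbers lie so close together, and none of them can be explained from the data at hand.

Because all three compounds were read at one concentration with values close to zero, the data leave open whether they would remain indistinguishable at any other concentration. From the compounds shown here alone, it also remains open whether an amine, a carboxylic acid or a longer alkoxy chain on this same carbon would give a step beyond the scatter.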